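Acetamido in place of trifluoromethyl: compound 1 to compound 4

A few compounds are considered here, and "the series" means these few. Any claim that something is new, unique, unknown or untested is made for them only; others in the source may bear on it.

Compound 1 `O=C(/C=C/c1ccc2c(c1)B(O)OC2)c1ccc(C(F)(F)F)cc1` has so far been tested only in an ADME assay on L929 cells (Mus musculus) for cytotoxicity, read by resazurin assay, with a stated time of 72 h; a lower number here means a stronger inhibitor, a higher number a weaker inhibitor. In this assay compound 1 gives > 10 ug/mL, which is a limit of the assay and not a number. Compound 3 `COc1cc(C(=O)/C=C/c2ccc3c(c2)B(O)OC3)ccc1[N+](=O)[O-]` likewise gives > 10 ug/mL in this assay, again a limit rather than a measured value. For the measured compounds named here, compound 2 `COc1cccc(C(=O)/C=C/c2ccccc2)c1` is the one member of the set with a number, giving 5.7 ug/mL in this assay. Going by the values given here, compound 1 therefore stands at the limit of > 10 ug/mL in this assay, at which 2 of the 3 values shown sit, and no pair of measured compounds differing in a single place is available, so no measured step size can be taken from the set.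

Compound 4 `CC(=O)Nc1ccc(C(=O)/C=C/c2ccc3c(c2)B(O)OC3)cc1` differs from compound 1 by acetamido in place of trifluoromethyl on an aromatic carbon.

Among the compounds with values here, with no measured step to lean on, the expectation for the step from compound 1 to compound 4 a step that the limit leaves unreadable from compound 1 to compound 4 is no change beyond the scatter, because compound 1 already sits at the limit of > 10 ug/mL in this assay, at which 2 of the 3 values shown sit, together with compound 3. Compound 4 is accordingly expected to give about 15 ug/mL in this assay, with a range of 6 ug/mL to 40 ug/mL, and most likely the assay would again report only the limit for compound 4.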

Compound 4, half-maximal inhibitory concentration: > 10 ug/mL
Compound 4: only a limit was reported (the forecaster's own chance of this, stated with the estimate: 70%); the middle value does not contradict the limit.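

In this assay neither compound 1 nor compound 4 gives a number, so the step between them cannot be read, and both stand at the same limit: the limit of > 10 ug/mL in this assay, at which 3 of the 4 values shown sit. The compounds shown leave open whether acetamido in place of trifluoromethyl on an aromatic carbon changes the half-maximal inhibitory concentration at all.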